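A few compounds are considered here, and "the series" means these few. Any claim that something is new, unique, unknown or untested is made for them only; others in the source may bear on it.

Measured so far in a functional assay on UACC-62 cells (Homo sapiens) for cytotoxicity, read by sulforhodamine B assay, with a stated time of 48 h, tested at 1 uM; on this read-out lower numbers stand for a stronger effect and higher numbers for a weaker effect at the one concentration tested:
- compound 1 `COc1ccc(C(=O)/C=C/c2cc(-c3cc(OC)c(OC)c(OC)c3)n[nH]2)cc1OC`: 95%
- compound 2 `COc1cc(-c2cc(/C=C/C(=O)c3ccc(F)c(F)c3)[nH]n2)cc(OC)c1OC`: 88%

Going by the values given here, only two compounds have been measured in this assay, and both give weak effects at the single concentration tested. Compound 1 and compound 2 cannot be told apart on these numbers: a number 7 percentage points lower from compound 1 to compound 2 (within the scatter). That step exchanges the aryl ring on the carbonyl carbon and leaves the other aryl ring untouched.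

Compound 3 `COc1cc(C(=O)/C=C/c2cc(-c3cc(OC)c(OC)c(OC)c3)n[nH]2)cc(OC)c1OC` differs from compound 1 in the opposite part of the molecule: methoxy in place of hydrogen on an aromatic carbon. The shared core of compound 1 stays as it is. Among the compounds with values here, no measured step touches this ring, so nothing observed bears directly on the change. Within the data shown here, the only measured comparison shows the read-out unmoved beyond scatter when the carbonyl-side ring was altered, and a weak effect at this concentration leaves little room for movement in either direction. Compound 3 is therefore expected to stay within the scatter of compound 1, a step of a number 3 percentage points lower from compound 1 to compound 3 (within the scatter). The estimated activity for compound 3 is 92%, with a range of 75% to 105%.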

Compound 3, a percentage reported as activity, at one concentration (the size of the read-out at that concentration, not a potency): 90%
Compound 3: middle estimate off by 2 percentage points, on the high side; low and high end bracket the measured number.
By their numbers in this assay, from the lowest: compounds 2, 3 and 1 (each within the scatter of the next).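

Going by these compounds alone, compound 3 gives the first reading of a change at this position: methoxy in place of hydrogen on an aromatic carbon, ortho to a methoxy group, comes to a number 5 percentage points lower from compound 1 to compound 3 (within the scatter) in this assay. At the one concentration tested, adding this group of 2 heavy atoms and 1 hydrogen-bond acceptor to the ring therefore leaves compound 3 indistinguishable from compound 1, so the read-out at this position tolerates the methoxy without a detectable shift. No evidence is available that bears on this result.

The compounds shown leave open whether an amine, a carboxylic acid or a longer alkoxy chain at this position would move the read-out. They also leave open whether a hydroxyl group here would give a number clearly apart from compound 1.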